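A few compounds are considered here, and "the series" means these few. Any claim that something is new, unique, unknown or untested is made for them only; others in the source may bear on it.

Measured so far in a functional assay on SW-620 cells (Homo sapiens) for antiproliferative activity, read by MTT assay, with a stated time of 24 h; on this read-out lower numbers stand for stronger inhibition and higher numbers for weaker inhibition:
Compound 1 `COc1cccc(/C=C/C(=O)c2ccc(OC)c3c2OC(C)(C)C=C3)c1` gives > 10000 nM, a limit of the assay.
Compound 2 `COc1ccc(C(=O)/C=C/c2ccc(F)cc2)c2c1C=CC(C)(C)O2` gives > 10000 nM, a limit of the assay.
Compound 3 `COc1ccc(C(=O)/C=C/c2ccsc2)c2c1C=CC(C)(C)O2` gives > 10000 nM, a limit of the assay.

Compound 3 stands at the assay limit, and so do the other two compounds shown: the limit of > 10000 nM in this assay, at which 3 of the 3 values shown sit. The steps a step that the two limits leave unreadable from compound 1 to compound 2, a step that the two limits leave unreadable from compound 1 to compound 3 and a step that the two limits leave unreadable from compound 2 to compound 3 are therefore unreadable, and no size or direction can be taken from them.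

Compound 4 `COc1ccc(C(=O)/C=C/c2ccc(Cl)c(Cl)c2)c2c1C=CC(C)(C)O2` differs from compound 3 by 3,4-dichlorophenyl in place of thiophen-3-yl on a double-bonded chain carbon bound to a double-bonded chain carbon. The measured steps among compounds 1, 2 and 3, all aryl exchanges at the same chain carbon, bear on this change only in that none of them moved a compound off the limit. Nothing measured points to a step in either direction for the move from compound 3 to compound 4, and the most likely outcome is again a limit.

Compound 4 is expected at 15000 nM in this assay, with a range of 4000 nM to 60000 nM, which as a step means a step that the limit leaves unreadable from compound 3 to compound 4 and is an estimate only.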

Compound 4, half-maximal inhibitory concentration: 7700 nM
Compound 4: middle estimate off by 1.9-fold (0.29 log units), on the high side, within the range that was stated.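

In this assay, 3,4-dichlorophenyl is the only aryl group shown at this chain carbon that gives a number rather than a limit, so this position can yield a readable value: the limit of > 10000 nM in this assay, at which 3 of the 4 values shown sit.

The exchange gives an at least 1.2-fold lower number from compound 3 to compound 4 (0.11 log units; that floor lies within the scatter), an at least 1.2-fold lower number from compound 2 to compound 4 (0.11 log units; that floor lies within the scatter) and an at least 1.2-fold lower number from compound 1 to compound 4 (0.11 log units; that floor lies within the scatter). Each is only a floor lying within the scatter, so compound 4 is not yet separated beyond the scatter from compound 1, compound 2 or compound 3, and the steps among those three cannot be read.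

Open, on these data alone, is whether a single chlorine, as in 4-chlorophenyl, would be enough to give a value at this chain carbon. Equally open, as far as these compounds go, is what an amine or a carboxylic acid on the aryl ring there would do.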